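Swapping a methyl-bearing ring for a chlorophenyl in a solubility series

The source may report more compounds than this note shows. Statements on the series, on what has been measured and on what is new or still open speak of the compounds shown alone.

Compound 2 `CCOC(=O)c1c(-c2cccc(C)c2)[nH]c2cc(OC)ccc2c1=O` sits at the top of the two numbers given in a physicochemical assay for solubility, in phosphate buffer, at pH 7.4 (a higher number here means a more soluble compound, a lower number a less soluble compound), where compound 2 gives 48000 nM. Its nearest neighbour is compound 3 `CCOC(=O)c1c(-c2ccc(Cl)c(Cl)c2)[nH]c2cccc(OC)c2c1=O`, which in this assay gives 39000 nM, a gap that lies within the scatter. Compound 1 `CCOC(=O)c1c(-c2ccc(Cl)cc2)[nH]c2cccc(OC)c2c1=O` reaches only a limit of this assay, giving > 100000 nM (the limit of > 100000 nM in this assay, at which 1 of the 3 values shown sits). Among the compounds with values here, the one measured step on a single site, an at least 2.5-fold lower number from compound 1 to compound 3 (0.40 log units; beyond the scatter), lowers the reading when a chloro enters in place of hydrogen. Compound 4 `CCOC(=O)c1c(-c2ccc(Cl)cc2)[nH]c2cc(OC)ccc2c1=O`, not yet measured, differs from compound 2 by 4-chlorophenyl in place of 3-methylphenyl on an aromatic carbon. Within the data shown here, no measured pair shows exactly this exchange; compound 1, which also carries a 4-chlorophenyl group, stands at the limit, while the only chloro-for-hydrogen step points the other way. Taken together, the expectation for a 1.1-fold lower number from compound 2 to compound 4 (0.03 log units; within the scatter) is a step no larger than the scatter. Compound 4 is therefore estimated at 45000 nM, within 18000 nM to 110000 nM.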

Compound 4, solubility: 3000 nM
For compound 4 the middle estimate is 15-fold (1.18 log units) above the measured one; the whole stated range lies above it.
By their numbers in this assay, from the lowest: compound 4; then compounds 3 and 2 (each within the scatter of the next). At a limit, above all of these: compound 1.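

In this assay, the exchange on the aromatic carbon next to the ring nitrogen gives a 16-fold lower number from compound 2 to compound 4 (1.20 log units; beyond the scatter), so this position is sensitive to the exchange even though both groups count the same heavy atoms, with no hydrogen-bond donors or acceptors and no net charge. The 4-chlorophenyl group does not set the reading by itself, since compound 4 carries it and gives 3000 nM. Compound 1 carries the same group on a core that differs only in the place of the methoxy group, and its reading is a limit, not a number: the limit of > 100000 nM in this assay, at which 1 of the 4 values shown sits.

The compounds shown leave open whether the step belongs to the chloro itself or to its place on the phenyl ring, which a 3-chlorophenyl or 4-methylphenyl group at this position would separate. On these data alone, how an amine on that ring would read also stays open.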